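Urea-to-thiourea swap and reversed linker in the quinoline series

The source may report more compounds than this note shows. Statements on the series, on what has been measured and on what is new or still open speak of the compounds shown alone.

Measured so far in a functional assay on HT-29 cells (Homo sapiens) for cytotoxicity, read by MTT assay, with a stated time of 72 h; on this read-out lower numbers stand for stronger inhibition and higher numbers for weaker inhibition:
compound 1 `COc1cc2c(Oc3ccc(NC(=O)N/N=C/c4cccs4)cc3F)ccnc2cc1OCCCN1CCCCC1` gives 770 nM
compound 2 `COc1cc2c(Oc3ccc(NC(=S)N/N=C/c4ccccc4)cc3F)ccnc2cc1OCCCN1CCCCC1` gives 210 nM

Within the data shown here, compound 2 holds the lower of the two numbers; the only neighbour is compound 1, and the difference between them, a 3.7-fold lower number from compound 1 to compound 2 (0.56 log units; beyond the scatter), lies beyond the scatter. That step exchanged both the five-membered ring and the oxygen of the linker at once, so the two parts cannot be separated on these numbers.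

Compound 3 `COc1cc2c(Oc3ccc(/C=N/NC(=O)Nc4ccccc4)cc3F)ccnc2cc1OCCCN1CCCCC1` is the next point. Relative to compound 2 the change is a group of 12 heavy atoms (8 carbon, 3 nitrogen, 1 oxygen; one six-membered aromatic ring of carbon only) in place of a group of 12 heavy atoms (8 carbon, 3 nitrogen, 1 sulfur; one six-membered aromatic ring of carbon only), on an aromatic carbon. The oxygen re-enters where the sulfur sat, and the order of the linker along the chain is turned round, while the six-membered aromatic ring of carbon only stays. Among the measured compounds shown here, only the step from compound 1 to compound 2 bears on it, and only in part: it ran in the sulfur direction and was confounded with the ring exchange. Reading it backwards for the oxygen alone, a modest rise in this assay is expected, with the reversal of the linker adding uncertainty rather than a direction. The expected step for compound 3 is a 2.4-fold higher number from compound 2 to compound 3 (0.38 log units; beyond the scatter), giving an estimate of 500 nM with a range of 150 nM to 2000 nM.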

Compound 3, half-maximal inhibitory concentration: 190 nM
For compound 3 the middle estimate is 2.6-fold (0.42 log units) above the measured one; measured number inside the range.
By their numbers in this assay, from the lowest: compounds 3 and 2 (each within the scatter of the next); then compound 1.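

In this assay the exchange at this aromatic carbon gives a 1.1-fold lower number from compound 2 to compound 3 (0.04 log units; within the scatter), so the oxygen form with the turned-round linker and the sulfur form with the original linker cannot be told apart on this read-out, and sulfur is not required for a number of this size. The comparison with the thiophene-type compound, a 4.1-fold lower number from compound 1 to compound 3 (0.61 log units; beyond the scatter), keeps the oxygen and still lies beyond the scatter, so the gap seen earlier between compound 1 and compound 2 cannot be credited to sulfur alone, although this step also carries the turned-round linker and so does not isolate the six-membered aromatic ring of carbon only. No measurement on hand bears on the reason for these numbers.

As far as these compounds go, the separate contributions of the oxygen-for-sulfur exchange and of the linker order stay open, since the two changed together between compound 2 and compound 3. Also open, from the compounds shown here alone, is how the terminal aromatic ring would respond to a substituent such as a chloro or methoxy group, and whether this read-out would hold for such groups at all.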